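Phenol in place of ethoxy on the shared core

A few compounds are considered here, and "the series" means these few. Any claim that something is new, unique, unknown or untested is made for them only; others in the source may bear on it.

Compound 2 `CCOC(=O)CCCCCOc1cccc(CN(C(=O)c2ccc(-c3cccc(OCC)c3)cc2)C(C)C)c1` stands at a limit of an ADME assay on HEK293 cells (Homo sapiens) for cytotoxicity, read by CellTiter-Glo and resazurin assay, with a stated time of 72 h; a lower number here means that less compound is needed, a higher number that more compound is needed for the effect: in this assay compound 2 gives > 22300 nM, which is the limit of > 22300 nM in this assay, at which 1 of the 2 values shown sits. Compound 1 `CCOC(=O)CCCCCOc1cccc(CN(C(=O)c2ccc(-c3cccc(-c4nnc(C)o4)c3)cc2)C(C)C)c1` likewise reaches only a limit, giving > 26000 nM in this assay, which is the limit of > 26000 nM in this assay, at which 1 of the 2 values shown sits. The step that the two limits leave unreadable from compound 1 to compound 2 therefore cannot be read. Compound 3 `CCOC(=O)CCCCCOc1cccc(CN(C(=O)c2ccc(-c3cccc(O)c3)cc2)C(C)C)c1` differs from compound 2 by hydrogen in place of ethyl on an oxygen on an aromatic ring. Among the compounds with values here, no measured step of readable size bears on this change, and both neighbours sit at limits, so a step that the limit leaves unreadable from compound 2 to compound 3 is expected, meaning no shift beyond the scatter. Compound 3 is estimated at 30000 nM, ranging from 10000 nM to 100000 nM, most likely again reported as a limit.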

Compound 3, half-maximal effective concentration: > 26000 nM
Compound 3 was reported as a limit; the forecaster's own chance of this, stated with the estimate: 80%; the middle value lies beyond the limit too.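

In this assay, within the data shown here, compound 3 gives > 26000 nM, a limit; compound 1 and compound 2 also stand at limits, so no step among the three can be read. As far as these compounds go, the concentration at which any of them reaches half-maximal effect in this assay stays open.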